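This account rests on a few compounds, and the source may have more. Where it says the series, first, only, none or still open, it means among the compounds named here.

Measured in an ADME assay on PA-1 cells (Homo sapiens) for cytotoxicity, read by MTT assay, with a stated time of 72 h; on this read-out lower numbers stand for stronger inhibition and higher numbers for weaker inhibition:
- compound 1 `COc1ccc(C2=C(c3cc(OC)c(OC)c(OC)c3)C(=O)C(OC(C)=O)C2)cc1OC(C)C`: > 100 ug/mL (a limit)
- compound 2 `COc1ccc(C2=C(c3cc(OC)c(OC)c(OC)c3)C(=O)C(O)C2)cc1`: < 1 ug/mL (a limit)
- compound 3 `COc1ccc(C2=C(c3cc(OC)c(OC)c(OC)c3)C(=O)C(O[SiH2]C(C)(C)C)C2)cc1`: 7 ug/mL

Among the measured compounds shown here, compound 3, at 7 ug/mL, holds the only exact number in the set. The other two values are limits. Compound 4 `COc1ccc(C2=C(c3cc(OC)c(OC)c(OC)c3)C(=O)C(O[SiH2]C(C)(C)C)C2)cc1OC(C)C` differs from compound 3 by isopropoxy in place of hydrogen on an aromatic carbon.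

For the measured compounds named here, the one measured step, an at least 7.0-fold higher number from compound 2 to compound 3 (0.84 log units; beyond the scatter), lies at a different place, on an oxygen on a saturated carbon, so it says little about this change. Going by the values given here, the only measured compound bearing isopropoxy is compound 1, whose > 100 ug/mL is a limit. That compound also differs from compound 3 at the oxygen on a saturated carbon, so it gives direction only, not size. In this assay a moderate move toward a higher number is therefore expected. The expected change is a 3.6-fold higher number from compound 3 to compound 4 (0.55 log units; beyond the scatter). Compound 4 is estimated at 25 ug/mL, with an expected range from 7 ug/mL to 100 ug/mL.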

Compound 4, half-maximal inhibitory concentration: 7.1 ug/mL
Compound 4: middle estimate off by 3.5-fold (0.55 log units), on the high side, within the range that was stated.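

In this assay, placing isopropoxy on this aromatic carbon, ortho to a methoxy group, leaves the read-out within the scatter, with a 1.0-fold higher number from compound 3 to compound 4 (0.01 log units; within the scatter). The earlier comparison could give only a direction for isopropoxy, but with this group present on both sides, the exchange on the oxygen on a saturated carbon alone gives an at least 14-fold lower number from compound 1 to compound 4 (1.14 log units; beyond the scatter). The size of that step rests on a limit for compound 1, so the true gap is not known: the limit of > 100 ug/mL in this assay, at which 1 of the 4 values shown sits.

The compounds shown leave open whether isopropoxy would also make no difference beyond the scatter with the hydrogen on that oxygen, as in compound 2. On these data alone, how an amine or a longer alkoxy chain such as hexyloxy would read on the same aromatic carbon also remains open.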